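A few compounds are considered here, and "the series" means these few. Any claim that something is new, unique, unknown or untested is made for them only; others in the source may bear on it.

Measured compounds:

Compound 2, `COCC(COC)n1cc(Br)nc(Nc2c(C)cc(OC)cc2C)c1=O`: 7.8 nM
Compound 1, `COCC(COC)n1cc(Cl)nc(Nc2c(Cl)cc(OCCF)cc2Cl)c1=O`: 210 nM

In an assay on frontal cortex for displacement of a labelled ligand from corticotropin-releasing factor receptor 1 (Rattus norvegicus), with a stated time of 2 h (on this read-out higher numbers stand for weaker inhibition and lower numbers for stronger inhibition), compound 2 gives 7.8 nM, the lowest of the two numbers available. Compound 1 gives 210 nM in this assay, a higher number that lies beyond the usual scatter. Among the compounds with values here, the two compounds differ in several places at once, so no single step between them can be read from these values.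

Compound 3, `COCC(COC)n1cc(Br)nc(Nc2c(C)cc(OCF)cc2C)c1=O`, differs from compound 2 in one place only: fluoro in place of hydrogen on a saturated chain carbon bound to an oxygen on an aromatic ring. Within the data shown here, no measured pair shows this particular change, so its effect in this assay has to be judged without a direct precedent. Given that small a change, the expected step from compound 2 to compound 3 is none beyond the scatter, with the direction left open. Compound 3 is therefore expected to give about 10 nM in this assay, with a range from 3 nM to 35 nM. That estimate corresponds to an expected step of a 1.3-fold higher number from compound 2 to compound 3 (0.11 log units; within the scatter).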

Compound 3, half-maximal inhibitory concentration in the corticotropin-releasing factor receptor 1 assay: 4.3 nM
Compound 3: the middle estimate sits 2.3-fold (0.37 log units) above what was measured, within the range that was stated.
By their numbers in the corticotropin-releasing factor receptor 1 assay, from the lowest: compounds 3 and 2 (each within the scatter of the next); then compound 1.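

Within the data shown here, the first measured step at this place, fluoro in place of hydrogen on a saturated chain carbon bound to an oxygen on an aromatic ring, shows in the corticotropin-releasing factor receptor 1 assay a 1.8-fold lower number from compound 2 to compound 3 (0.26 log units; within the scatter), so methoxy to fluoromethoxy is tolerated on this core and the two compounds cannot be told apart on this read-out. In the corticotropin-releasing factor receptor 1 assay compound 2 gives 7.8 nM and compound 3 gives 4.3 nM. In a physicochemical assay for lipophilicity, using the shake flask method, in phosphate buffer, measured as octanol-water partition, at pH 7.4 (on this read-out lower numbers stand for lower lipophilicity and higher numbers for higher lipophilicity), compound 2 gives 2.8 and compound 3 gives 2.9. In the physicochemical assay the same change gives a number 0.10 log units higher from compound 2 to compound 3 (within the scatter), so they cannot be told apart on that read-out either. Nothing available explains these results.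

The compounds shown leave open whether a larger group at this place, such as trifluoromethoxy or a longer alkoxy chain, would also be tolerated. They also leave open whether fluoromethoxy would be tolerated as well with chloro in place of the methyl groups on the aromatic ring.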